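Branching the Amide Chain: Propyl Becomes Isopropyl

This account rests on a few compounds, and the source may have more. Where it says the series, first, only, none or still open, it means among the compounds named here.

Three compounds built on one shared core differ only in the group attached to the amide carbonyl. Compound 1 `COc1cc2c(cc1OC)C(CC(=O)N(C)C)CC2` carries a dimethylamino group, compound 2 `CCN(CC)C(=O)CC1CCc2cc(OC)c(OC)cc21` a diethylamino group, and compound 3 `CCCNC(=O)CC1CCc2cc(OC)c(OC)cc21` a propylamino group. In a functional assay on the whole organism (strain Wistar) for inhibition, with Rattus norvegicus as the target, read by paw edema, with stated times of 60 min and 24 h, at a dose of 100 mg/kg by the oral route (on this read-out higher numbers stand for more inhibition at the one dose given (going by the name of the read-out) and lower numbers for less inhibition), compound 1 gives 23.3%, compound 2 gives 16.7%, and compound 3 gives 26.7%. Compound 3 therefore shows the highest of the three numbers, but none of the gaps separates it from the others in a reliable way: a number 3.4 percentage points higher from compound 1 to compound 3 (within the scatter), a number 10 percentage points higher from compound 2 to compound 3 (within the scatter), and a number 6.6 percentage points lower from compound 1 to compound 2 (within the scatter).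

Compound 4 `COc1cc2c(cc1OC)C(CC(=O)NC(C)C)CC2` is the next variation, differing from compound 3 by isopropyl in place of propyl on an amide-type nitrogen. The three measured steps all exchange one group for another on the same amide nitrogen, and each stayed within the scatter, so a rearrangement of the same atoms on that nitrogen is not expected to move the read-out in this assay beyond the scatter either. The expected step is a number 1.7 percentage points lower from compound 3 to compound 4 (within the scatter), essentially flat. Compound 4 is accordingly estimated to give 25%, with a range from 12% to 38%.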

Compound 4, a percentage reported as inhibition, in the whole organism at one dose (the size of the read-out at that dose, not a potency): 30%
Beside the measured number, compound 4's estimate is 5 percentage points below it; the measured number falls inside the stated range.
By their numbers in this assay, from the lowest: compounds 2, 1, 3 and 4 (each within the scatter of the next, the first and the last beyond it).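

In this assay, moving from a straight propyl to a branched isopropyl on the amide-type nitrogen, with the same atoms joined differently, gives a number 3.3 percentage points higher from compound 3 to compound 4 (within the scatter), so this rearrangement does not separate the two compounds. Within the data shown here, the isopropylamino group does provide the only step in this set that clears the scatter, a number 13.3 percentage points higher from compound 2 to compound 4 (beyond the scatter), a modest step, while a number 6.7 percentage points higher from compound 1 to compound 4 (within the scatter) does not clear it. No measurement at hand explains why the diethylamino and isopropylamino compounds separate.

On these data alone, it remains open whether a tert-butyl or cyclopropyl group on the same nitrogen would stand clear of the scatter from compound 3 or compound 4. The plain primary amide, with no carbon group on that nitrogen, is also open, and results at a single dose give no measure of potency for any of these compounds.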